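Fluoro for Chloro: Expected Oral Exposure of Compound 4

The source may report more compounds than this note shows. Statements on the series, on what has been measured and on what is new or still open speak of the compounds shown alone.

Of the compounds shown here, three have been measured in an in vivo ADME assay on the whole organism for pharmacokinetics, with Rattus norvegicus as the target, at a dose of 3 mg/kg by the oral route; on this read-out higher numbers stand for higher exposure at the dose given and lower numbers for lower exposure: compound 1 `Cc1ccc(-c2cc(Cl)ccc2OCc2ccccc2)n1-c1cc(Br)cc(C(=O)O)c1` gives 310 nM; compound 2 `CC(=O)Nc1cc(C(=O)O)cc(-n2c(C)ccc2-c2cc(C(F)(F)F)ccc2OCc2ccccc2)c1` gives 20 nM; compound 3 `CC(=O)Nc1cc(C(=O)O)cc(-n2c(C)ccc2-c2cc(Cl)ccc2OCc2ccc(F)cc2)c1` gives 2080 nM.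

Compound 3 thus stands highest of the three numbers, with compound 1 nearest and compound 2 furthest, and both gaps lie beyond the scatter. Compound 4 `CC(=O)Nc1cc(C(=O)O)cc(-n2c(C)ccc2-c2cc(F)ccc2OCc2ccc(F)cc2)c1` is the next one to be measured in this assay; it differs from compound 3 by fluoro in place of chloro on an aromatic carbon. Within the data shown here, no step between two measured compounds isolates this kind of change, so the expectation rests on compound 3 alone. A step from compound 3 to compound 4 of a 1.4-fold lower number from compound 3 to compound 4 (0.14 log units; within the scatter) is expected in this assay, which is not beyond the scatter. Compound 4 is therefore estimated at 1500 nM, with a range from 450 nM to 5000 nM.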

Compound 4, maximal plasma concentration: 2950 nM
The estimate for compound 4 lay 2.0-fold (0.29 log units) below the measured number; the measured number falls inside the stated range.
By their numbers in this assay, from the lowest: compound 2; then compound 1; then compounds 3 and 4 (each within the scatter of the next).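

With fluoro in place of chloro on this aromatic carbon, para to the (4-fluorobenzyl)oxy group, this assay shows a 1.4-fold higher number from compound 3 to compound 4 (0.15 log units; within the scatter), so this exchange of halogens leaves the read-out within the scatter. Among these compounds, no earlier pair isolated a single change at this position, and this step is the first to do so. Nothing shown explains the result. Still open, going by these compounds, is how a methoxy group or a nitrile at this position would behave. Also open, on these data alone, is whether the same exchange would read alike with a plain benzyloxy group in place of the (4-fluorobenzyl)oxy group.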